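The source may report more compounds than this note shows. Statements on the series, on what has been measured and on what is new or still open speak of the compounds shown alone.

In a functional assay on the whole organism for antagonist activity, with Mus musculus as the target (a higher number here means that more compound is needed for the effect, a lower number that less compound is needed), compound 2 `CCC(=O)N(c1ccc(Br)cc1)C1CCCC1N(C)C` gives 3 mg/kg and compound 1 `CCC(=O)N(c1cccc(OC)c1)C1CCCC1N(C)C` gives 4 mg/kg so these two sit within the scatter of each other. Compound 3 `CCC(=O)N(c1ccc(Br)c(Br)c1)C1CCCC1N(C)C` gives 0.2 mg/kg and stands clearly lower than both. Compound 4 `CCC(=O)N(c1ccc(C(C)=O)cc1)C1CCCC1N(C)C` is still unmeasured and differs from compound 2 by acetyl in place of bromo on an aromatic carbon, para to a large group acetyl in place of bromo on an aromatic carbon and nothing else. Among the compounds with values here, the one measured step that bears on this is a 15-fold lower number from compound 2 to compound 3 (1.18 log units; beyond the scatter) and it puts bromo in place of hydrogen on an aromatic carbon while the existing bromo stays. Within the data shown here, no measured step replaces that bromo, so direction remains open. That step does show that one aromatic substituent can move the number a long way, so the range must stay wide. Expected here is a 1.7-fold higher number from compound 2 to compound 4 (0.22 log units; within the scatter) with no step beyond the scatter and a slight lean towards a higher number. For compound 4 the estimate is 5 mg/kg with an expected span of 1 mg/kg to 25 mg/kg in this assay for now.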

Compound 4, dose for half-maximal effect: 40 mg/kg
Beside the measured number, compound 4's estimate is 8.0-fold (0.90 log units) below it; measured number above the stated range.
By their numbers in this assay, from the lowest: compound 3; then compounds 2 and 1 (each within the scatter of the next); then compound 4.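

In this assay, the place para to a large group proves highly sensitive to what stands there: acetyl in place of bromo gives a 13-fold higher number from compound 2 to compound 4 (1.12 log units; beyond the scatter) and so marks this exchange as a large step. Within the data shown here, the earlier step, a 15-fold lower number from compound 2 to compound 3 (1.18 log units; beyond the scatter) with bromo added while the existing bromo stayed, did not touch this substituent, so the present result is the first to show that replacing it matters, and the number moves in the opposite direction. No measurement at hand explains the rise.

On these data alone, it remains open whether chloro, methyl, nitrile or a longer acyl chain at this place would give a number near that of compound 2 or near that of compound 4. Also open, as far as these compounds go, is whether the acetyl exchange would have a similar effect with the second bromo of compound 3 present.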